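Thiosemicarbazone series against duckweed: from methoxy to fluoro

The source may hold more compounds than are shown below. What is called first, only, known or untested is meant among the compounds shown, and "the series" means these compounds.

Measured compounds:
Compound 1, `CCCCCCNC(=S)N/N=C1\C(=O)Nc2ccc([N+](=O)[O-])cc21`, 35%
Compound 2, `Cc1cccc(NC(=S)N/N=C2\C(=O)Nc3ccc([N+](=O)[O-])cc32)c1`, 20%
Compound 3, `COc1ccc(NC(=S)N/N=C2\C(=O)Nc3ccc([N+](=O)[O-])cc32)cc1`, 15%

In a functional assay on the whole organism for inhibition, with Lemna aequinoctialis as the target, tested at 100 ug/mL (a lower number here means less inhibition of growth, a higher number more inhibition of growth at the concentration tested), compound 3 gives the lowest of the three numbers. Its nearest neighbour is compound 2 with 20%, a gap within the scatter, while compound 1 with 35% lies furthest away; the step of a number 20 percentage points lower from compound 1 to compound 3 (beyond the scatter) is beyond the scatter, as is a number 15 percentage points lower from compound 1 to compound 2 (beyond the scatter). The step of a number 5 percentage points lower from compound 2 to compound 3 (within the scatter) is within the scatter.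

Compound 4, `O=C1Nc2ccc([N+](=O)[O-])cc2/C1=N/NC(=S)Nc1ccc(F)cc1`, has not yet been measured in this assay. It differs from compound 3 in one place: fluoro in place of methoxy on an aromatic carbon. Within the data shown here, no measured step replaces one substituent on the phenyl ring by another of this kind; the nearest comparison is the change from 3-methylphenyl to 4-methoxyphenyl, which stayed within the scatter. The two phenyl-bearing compounds, compound 2 and compound 3, both sit well below compound 1. No change beyond the scatter is therefore expected, and the step is estimated as a number 2 percentage points higher from compound 3 to compound 4 (within the scatter). For compound 4 the value in this assay is estimated at 17%, between 5% and 32%.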

Compound 4, percent growth inhibition at one concentration: 15%
Estimate against measurement, compound 4: 2 percentage points above; low and high end bracket the measured number.
By their numbers in this assay, from the lowest: compounds 3, 4 and 2 (each within the scatter of the next); then compound 1.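

In this assay, among these compounds, the step of no change at the digits printed from compound 3 to compound 4 (within the scatter) gives the first direct comparison of two substituents at this place on the phenyl ring, para to a large group, and exchanging methoxy for fluoro leaves the number unmoved. The step of a number 5 percentage points lower from compound 2 to compound 4 (within the scatter) also stays within the scatter, whereas the step of a number 20 percentage points lower from compound 1 to compound 4 (beyond the scatter) lies beyond it, so all three phenyl-bearing compounds now sit apart from the hexyl compound. Nothing measured on these compounds offers an explanation for these numbers.

From the compounds shown here alone, whether an amine or a carboxylic acid at this place on the phenyl ring would leave the number where it is remains open. Going by these compounds, it is also open whether a chain longer than hexyl would move the number away from that of compound 1.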